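The compounds below may be only part of what the source reports. "The series", "measured", "known", "first", "only" and "open" are said of these compounds alone.

Compound 1 `CC1=C(N2CC2)C(=O)C(CC(C)OC(N)=O)=C(N2CC2)C1=O` is a core carrying two aziridin-1-yl groups and a methyl group, with a seven-atom chain ending in a carbamate. In a functional assay on L1210 cells (Mus musculus), with a stated time of 1 days (on this read-out lower numbers stand for lower potency and higher numbers for higher potency (the scale is a negative logarithm)), compound 1 gives 5.86. Compound 2 `CCC1=C(N2CC2)C(=O)C(CCOC(N)=O)=C(N2CC2)C1=O` differs in its methyl and in its chain; in this assay compound 2 gives 5.98, a number that sits within the scatter of compound 1, so the two cannot be told apart on these measurements.

Compound 3 `CC1=C(N2CC2)C(=O)C(C(C)C)=C(N2CC2)C1=O` is the next step from compound 1: a group of 3 heavy atoms (3 carbon; no ring) in place of a group of 7 heavy atoms (4 carbon, 1 nitrogen, 2 oxygen; no ring), on a double-bonded ring carbon. For the measured compounds named here, no measured pair shows a change of this kind, so its size is not known from these data. Because the remaining compound 2 shows 5.98, with no carbamate removed, nothing anchors the expectation beyond the two measured values; a modest lowering is expected, from compound 1 to compound 3 of a number 0.46 log units lower from compound 1 to compound 3 (beyond the scatter). For compound 3 the expected value in this assay is 5.4, within the range of 4.7 to 6.1.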

Compound 3, logarithm of the reciprocal of the active concentration, log(1/C): 4.96
Compound 3: the middle estimate sits 0.44 log units above what was measured, within the range that was stated.
By their numbers in this assay, from the lowest: compound 3; then compounds 1 and 2 (each within the scatter of the next).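

For the compounds shown here, at this position on the double-bonded ring carbon, compound 3 gives the first change that can be read on its own, since compounds 1 and 2 differ in two places. In this assay, putting isopropyl in place of the chain ending in a carbamate gives a number 0.90 log units lower from compound 1 to compound 3 (beyond the scatter) and so the read-out does respond to the group at this position. The two groups are therefore not interchangeable here, at least on this shared core with its methyl group, and no measurement at hand explains the step.

From the compounds shown here alone, it remains open whether the step follows the carbamate end or the overall size of the chain. A plain butyl chain, or the same chain ending in a hydroxyl group or an amine, would help to separate those two readings.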